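This account rests on a few compounds, and the source may have more. Where it says the series, first, only, none or still open, it means among the compounds named here.

Compound 1, `CCCOCCn1c(N2CCN(C)CC2)nc2ccccc21`: in a functional assay on ileum for inhibition of histamine H1 receptor (Cavia porcellus) (a higher number here means a weaker inhibitor, a lower number a stronger inhibitor), compound 1 gives 20 nM.
Compound 2, `CCOCCn1c(N2CCN(c3ccccc3)CC2)nc2ccccc21`: in this assay compound 2 reaches only a limit of the assay, > 10000 nM.

Compound 1 therefore holds the only real number shown. For compound 2 there is only (the limit of > 10000 nM in this assay, at which 1 of the 2 values shown sits), not a number. Compound 3, `CCCC(C)Cn1c(N2CCN(C)CC2)nc2ccccc21`, is not yet measured; it differs from compound 1 in one place: 1-methylbutyl in place of propoxymethyl on a saturated chain carbon bound to an aromatic nitrogen. Within the data shown here, no measured pair differs in a single place, so no step can be read off from the data. The change is expected to shift the value in this assay only slightly, within or just beyond the scatter, if anything toward a weaker inhibitor. Compound 3 is expected to give 40 nM in this assay, somewhere between 8 nM and 200 nM, which means an estimated step of a 2.0-fold higher number from compound 1 to compound 3 (0.30 log units; within the scatter).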

Compound 3, half-maximal inhibitory concentration: 500 nM
Compound 3: the middle estimate sits 13-fold (1.10 log units) below what was measured; the whole stated range lies below it.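

Replacing propoxymethyl with 1-methylbutyl at this position gives, in this assay, a 25-fold higher number from compound 1 to compound 3 (1.40 log units; beyond the scatter). So this position responds strongly to the change, even though both groups have 5 heavy atoms and neither contains a ring; the oxygen-containing propoxymethyl belongs to the stronger inhibitor of this pair. Nothing shown here explains the size of this step.

The compounds leave open whether the loss follows from removing the oxygen or from adding the methyl branch. A straight pentyl chain on the same core could separate those two changes.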